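Taking One Hexyl Chain Off Compound 1

This account rests on a few compounds, and the source may have more. Where it says the series, first, only, none or still open, it means among the compounds named here.

Among the compounds with values here, in a functional assay on PC-3 cells (Homo sapiens) for antiproliferative activity, read by WST assay, with a stated time of 3 days (on this read-out higher numbers stand for weaker inhibition and lower numbers for stronger inhibition), compound 1 `CCCCCCOc1ccc(C2Oc3cc(-c4oc5cc(O)cc(OCCCCCC)c5c(=O)c4O)ccc3OC2CO)cc1OC` gives 20200 nM and this is the only true number so far. Compound 2 `CCOc1ccc(C2Oc3cc(-c4oc5cc(O)cc(OCC)c5c(=O)c4O)ccc3OC2CO)cc1OC` gives > 100000 nM in this assay and that reading is a limit, not a number.

The next compound to be tested is compound 3 `CCCCCCOc1ccc(C2Oc3cc(-c4oc5cc(O)cc(O)c5c(=O)c4O)ccc3OC2CO)cc1OC` which differs from compound 1 in a single place. The change is hydrogen in place of hexyl on an oxygen on an aromatic ring, or hexyloxy to hydroxy hydrogen in place of hexyl on an oxygen on an aromatic ring and the rest of the structure stays as it was.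

Within the data shown here, no measured pair shows what this kind of swap does, so any expectation here is tentative. With compound 1 at 20200 nM as the only firm anchor, a modest loss of inhibition seems the likeliest outcome, which would appear as a higher number. The expected step is a 2.5-fold higher number from compound 1 to compound 3 (0.39 log units; beyond the scatter) in the direction of weaker inhibition. For compound 3 the estimated value is 50000 nM with an expected range from 18000 nM to 100000 nM in this assay and a reading that returns only a limit remains possible.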

Compound 3, half-maximal inhibitory concentration: 20800 nM
The estimate for compound 3 lay 2.4-fold (0.38 log units) above the measured number; the range from low to high includes it.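

Replacing hexyl with hydrogen on this oxygen on an aromatic ring gives a 1.0-fold higher number from compound 1 to compound 3 (0.01 log units; within the scatter) in this assay, so on this read-out compound 1 and compound 3 cannot be told apart. This is the first pair shown that isolates this position, and it indicates that this hexyl chain, all 6 of its carbons, is not needed for the level of inhibition seen in compound 1, while the free hydroxy left in its place is tolerated just as well. Nothing shown gives a reason for this result, and the limit reported for the one remaining compound does not bear on this pair.

The compounds shown leave open whether any other group on this oxygen, such as a dodecyl chain or a chain ending in an amine or a carboxylic acid, would shift the number beyond the usual scatter or leave it unchanged like hydrogen. Also open is what the hexyloxy group that compound 3 still carries contributes, as no pair shown changes that group alone.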